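This account rests on a few compounds, and the source may have more. Where it says the series, first, only, none or still open, it means among the compounds named here.

Measured compounds:
Compound 1, `CCCn1c(=O)[nH]c2nc(-c3ccc(S(=O)(=O)N4CCN(c5cccc(F)c5)CC4)cc3)[nH]c2c1=O`: 34%
Compound 2, `CCCn1c(=O)[nH]c2nc(-c3ccc(S(=O)(=O)N4CCN(C(C)c5ccccc5)CC4)cc3)[nH]c2c1=O`: 42%

In an assay on CHO cells for displacement of a labelled ligand from adenosine receptor A1 (Homo sapiens), read by scintillation counting, with a stated time of 90 min, tested at 1 uM, in the presence of a further agent that is not named here (a higher number here means more inhibition at the concentration tested (going by the name of the read-out), a lower number less inhibition), compound 2 gives 42%, the higher of the two numbers, though the gap between the two is a number 8 percentage points higher from compound 1 to compound 2 (within the scatter) and so the two compounds cannot be told apart on this assay. Compound 3, `CCCn1c(=O)[nH]c2nc(-c3ccc(S(=O)(=O)N4CCN(c5ccc(I)cc5)CC4)cc3)[nH]c2c1=O`, has not been measured in this assay. It differs from compound 2 by 4-iodophenyl in place of 1-phenylethyl on an amine nitrogen in a ring. Within the data shown here, the one measured step that bears on this position is the step from compound 1 to compound 2, in which a 1-phenylethyl replaced a 3-fluorophenyl on the same ring nitrogen and the number rose by a number 8 percentage points higher from compound 1 to compound 2 (within the scatter). The change to compound 3 goes the other way in kind, returning an aromatic ring directly on that nitrogen, as in compound 1. A step of a number 6 percentage points lower from compound 2 to compound 3 (within the scatter) is therefore expected, which stays inside the scatter. On that basis compound 3 is estimated at 36% in this assay, with a range from 20% to 52%.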

Compound 3, a percentage reported as inhibition, at one concentration (the size of the read-out at that concentration, not a potency): 24%
Compound 3: the middle estimate sits 12 percentage points above what was measured, within the range that was stated.
By their numbers in this assay, from the lowest: compounds 3, 1 and 2 (each within the scatter of the next, the first and the last beyond it).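

In this assay, putting 4-iodophenyl in place of 1-phenylethyl on the amine nitrogen in the ring gives a number 18 percentage points lower from compound 2 to compound 3 (beyond the scatter), so the group at this position can move the read-out by more than the scatter, which the earlier pair could not show. That holds only for this one pair: the swap of 3-fluorophenyl for 4-iodophenyl gives a number 10 percentage points lower from compound 1 to compound 3 (within the scatter), and compound 1, which also has a phenyl ring carried directly on that nitrogen, stays within the scatter of compound 2 in a number 8 percentage points higher from compound 1 to compound 2 (within the scatter), so the three compounds do not divide cleanly into two groups. Nothing measured here accounts for the step from compound 2 to compound 3.

As far as these compounds go, the step swaps the 1-phenylethyl group for an iodine-bearing ring in one move, so it remains open whether the loss of the 1-phenylethyl group or the arrival of the iodine matters more, and a plain phenyl or a benzyl on that nitrogen would help to separate the two. Also open, from the compounds shown here alone, is how a chlorine or a methoxy group in place of the iodine would read, and whether these differences at a single concentration would carry over to potency.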